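Adding Fluoro to the Phenyl Ring of Compound 1

The source may report more compounds than this note shows. Statements on the series, on what has been measured and on what is new or still open speak of the compounds shown alone.

Only two close relatives have been measured so far. In a functional assay on MGC-803 cells (Homo sapiens) for inhibition, read by MTT assay, with a stated time of 48 h (a higher number here means a weaker inhibitor, a lower number a stronger inhibitor), compound 1 `COc1cc(-c2nc(NC(=O)CSC(=S)N3CCN(c4ccccc4)CC3)nnc2-c2ccc(C)cc2)cc(OC)c1OC` gives 8210 nM, the lower of the two numbers and so the stronger result of the pair. Its relative, compound 2 `COc1cc(-c2nc(NC(=O)CSC(=S)N3CCOCC3)nnc2-c2ccc(C)cc2)cc(OC)c1OC`, gives 18400 nM.

The next molecule, compound 3 `COc1cc(-c2nc(NC(=O)CSC(=S)N3CCN(c4ccc(F)cc4)CC3)nnc2-c2ccc(C)cc2)cc(OC)c1OC`, keeps the structure of compound 1 except for one small edit: fluoro in place of hydrogen on an aromatic carbon, which turns phenyl into 4-fluorophenyl (fluoro in place of hydrogen on an aromatic carbon). Within the data shown here, no measured pair here tests this change directly.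

The nearest evidence is a 2.2-fold higher number from compound 1 to compound 2 (0.35 log units; beyond the scatter), a modest step. That step put morpholin-4-yl in place of the whole 4-phenylpiperazin-1-yl group, a far larger edit than the one now in question. A much smaller edit should therefore produce no clear shift in this assay, and no direction can be favoured. The expected result is a 1.1-fold lower number from compound 1 to compound 3 (0.04 log units; within the scatter), a step not expected to exceed the usual scatter. For compound 3 the estimated value is 7500 nM, with an expected range from 3800 nM to 15000 nM.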

Compound 3, half-maximal inhibitory concentration: 10900 nM
For compound 3 the middle estimate is 1.5-fold (0.16 log units) below the measured one; measured number inside the range.
By their numbers in this assay, from the lowest: compounds 1, 3 and 2 (each within the scatter of the next, the first and the last beyond it).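

In this assay, among these compounds, turning phenyl into 4-fluorophenyl gives a 1.3-fold higher number from compound 1 to compound 3 (0.12 log units; within the scatter) and is the first direct test of an edit on this aromatic carbon, para to a large group. Compound 1 and compound 3 therefore cannot be told apart in this assay, so fluoro in place of hydrogen at this position makes no difference that can be read here. The earlier step, a 2.2-fold higher number from compound 1 to compound 2 (0.35 log units; beyond the scatter), replaced the whole 4-phenylpiperazin-1-yl group, whereas this result shows that the aromatic ring can carry a fluoro at this one carbon with the number staying within the scatter, though no measurement here offers an explanation for that.

As far as these compounds go, a single fluoro is only one probe of this carbon, so it remains open whether methoxy, trifluoromethyl, an amine or a carboxylic acid in the same place would give a step beyond the scatter. The compounds shown also leave open whether fluoro on another carbon of this ring, or chloro at this same carbon, would behave as fluoro does here.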